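Swapping Cyclohexenyl for Fluorophenyl on the Shared Core

The compounds below may be only part of what the source reports. "The series", "measured", "known", "first", "only" and "open" are said of these compounds alone.

Compound 1 `C[C@H](NC(=O)c1cnnn1Cc1ccc(C(F)(F)F)cc1)c1ccc(C(=O)O)cc1` is tested in a functional assay on CHO cells for antagonist activity at prostaglandin E2 receptor EP4 subtype (Homo sapiens), read by calcium flux, with a stated time of 15 min; on this read-out higher numbers stand for weaker inhibition and lower numbers for stronger inhibition. There compound 1 reaches only the assay limit of > 10000 nM (the limit of > 10000 nM in this assay, at which 1 of the 2 values shown sits). Compound 2 `C[C@H](NC(=O)c1c(C2=CCCCC2)nnn1Cc1ccc(C(F)(F)F)cc1)c1ccc(C(=O)O)cc1` gives 183 nM in this assay, the only true number shown; the step of an at least 54-fold lower number from compound 1 to compound 2 (1.73 log units; beyond the scatter) is large. Compound 3 `C[C@H](NC(=O)c1c(-c2ccc(F)cc2)nnn1Cc1ccc(C(F)(F)F)cc1)c1ccc(C(=O)O)cc1` differs from compound 2 by 4-fluorophenyl in place of cyclohex-1-en-1-yl on an aromatic carbon. Within the data shown here, no measured step covers this exchange, and the large step from compound 1 to compound 2 shows only that a ring at this carbon matters. For compound 3 a change of about a 1.2-fold lower number from compound 2 to compound 3 (0.09 log units; within the scatter) is expected, within the scatter, giving an estimated 150 nM (range 40 nM to 600 nM).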

Compound 3, half-maximal inhibitory concentration: 57.9 nM
Compound 3: middle estimate off by 2.6-fold (0.41 log units), on the high side, and the stated range covers the measured number.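

The ring at this carbon need not be the non-aromatic cyclohex-1-en-1-yl: the aromatic 4-fluorophenyl gives stronger inhibition in this assay, with a 3.2-fold lower number from compound 2 to compound 3 (0.50 log units; beyond the scatter). Against hydrogen at the same carbon, the change is an at least 170-fold lower number from compound 1 to compound 3 (2.23 log units; beyond the scatter). That size has no fixed end, as compound 1 stands at a limit of the assay: the limit of > 10000 nM in this assay, at which 1 of the 3 values shown sits.

The exchange changes the ring and adds fluorine together, so the two contributions cannot be separated here. From the compounds shown here alone, whether an unsubstituted phenyl, a saturated cyclohexyl or a ring bearing an amine would do as well remains open.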